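Para substituent series: from methyl to hydrogen

The source may report more compounds than this note shows. Statements on the series, on what has been measured and on what is new or still open speak of the compounds shown alone.

Measured in an ADME assay on U2OS cells (Homo sapiens) for cytotoxicity; on this read-out lower numbers stand for higher toxicity in this test and higher numbers for lower toxicity in this test:
- compound 1 `CC(C)(C)c1ccc(-c2nccc3[nH]c(C(C)(C)O)cc23)cc1` gives 35300 nM
- compound 2 `CC(C)(O)c1cc2c(-c3ccc(F)cc3)nccc2[nH]1` gives 93600 nM
- compound 3 `Cc1ccc(-c2nccc3[nH]c(C(C)(C)O)cc23)cc1` gives 38500 nM

Compound 3 stands with compound 1 in the lower part of this small set, as a 1.1-fold higher number from compound 1 to compound 3 (0.04 log units; within the scatter), whereas the other comparison is a 2.4-fold lower number from compound 2 to compound 3 (0.39 log units; beyond the scatter).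

The next compound is compound 4 `CC(C)(O)c1cc2c(-c3ccccc3)nccc2[nH]1`, and the change is hydrogen in place of methyl on an aromatic carbon, para to a large group. Among the measured compounds shown here, no measured compound carries hydrogen at this carbon, so only substitutions among the other groups bear on it. The steps are a 2.7-fold higher number from compound 1 to compound 2 (0.42 log units; beyond the scatter) and a 1.1-fold higher number from compound 1 to compound 3 (0.04 log units; within the scatter). With compound 2 at 93600 nM as the only clear outlier, a modest move towards higher numbers is expected, not one beyond the scatter.

The expected change is a 1.4-fold higher number from compound 3 to compound 4 (0.15 log units; within the scatter). For compound 4 the estimated value is 55000 nM, with an expected range of 30000 nM to 100000 nM.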

Compound 4, half-maximal cytotoxic concentration: 22200 nM
Estimate against measurement, compound 4: 2.5-fold (0.39 log units) above; measured number outside the range, below it.
By their numbers in this assay, from the lowest: compounds 4, 1 and 3 (each within the scatter of the next); then compound 2.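

In this assay hydrogen in place of methyl at this carbon, para to a large group, gives a step within the scatter (a 1.7-fold lower number from compound 3 to compound 4 (0.24 log units; within the scatter)), and hydrogen in place of tert-butyl does the same (a 1.6-fold lower number from compound 1 to compound 4 (0.20 log units; within the scatter)), so hydrogen, methyl and tert-butyl are not separated here. Fluoro alone stands apart from hydrogen, with a step beyond the scatter (a 4.2-fold lower number from compound 2 to compound 4 (0.62 log units; beyond the scatter)), and compound 2 therefore remains the only compound in the series with a clearly higher number. No supporting data are available to explain this difference.

On these data alone, whether the higher number belongs to fluoro alone or extends to chloro, methoxy or a nitrile at this carbon remains open. Also open, as far as these compounds go, is whether fluoro on another carbon of the same ring would give a similar number.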